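This account rests on a few compounds, and the source may have more. Where it says the series, first, only, none or still open, it means among the compounds named here.

Within the data shown here, compound 1 `CCCCNc1nc(N)nc(C)c1CCCCc1ccccc1` gives 857 nM in an assay on HEK293 cells for agonist activity at Toll-like receptor 8 (Homo sapiens), read by spectrophotometry (a lower number here means that less compound is needed, a higher number that more compound is needed for the effect), the highest of the three numbers measured so far. Compound 2 `CCCCNc1nc(N)nc(C)c1CCCN1CCCCC1` gives 133 nM and compound 3 `CCCCNc1nc(N)nc(C)c1CCCN(C)C` gives 126 nM. The steps of a 6.4-fold lower number from compound 1 to compound 2 (0.81 log units; beyond the scatter) and a 6.8-fold lower number from compound 1 to compound 3 (0.83 log units; beyond the scatter) both replace benzyl with piperidin-1-yl or dimethylamino, and between those two groups the step is a 1.1-fold lower number from compound 2 to compound 3 (0.02 log units; within the scatter). Compound 4 `CCCCCc1c(C)nc(N)nc1NCCCC` instead carries methyl in place of phenyl on a saturated chain carbon, four bonds along the chain from an aromatic carbon. Among the measured compounds shown here, no measured step pairs phenyl against methyl, so this change is untested; the two steps show only that benzyl at the chain end is not what keeps the number of compound 1 high. A small step, a 1.2-fold lower number from compound 1 to compound 4 (0.09 log units; within the scatter), is therefore expected, with the direction uncertain. Compound 4 is expected at 700 nM, in the range 250 nM to 2000 nM.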

Compound 4, half-maximal effective concentration: 1220 nM
For compound 4 the middle estimate is 1.7-fold (0.24 log units) below the measured one; low and high end bracket the measured number.
By their numbers in this assay, from the lowest: compounds 3 and 2 (each within the scatter of the next); then compounds 1 and 4 (each within the scatter of the next).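

Methyl in place of phenyl gives a 1.4-fold higher number from compound 1 to compound 4 (0.15 log units; within the scatter), so the number of compound 1 does not depend on the terminal phenyl. Ethyl in place of dimethylamino gives a 9.7-fold higher number from compound 3 to compound 4 (0.99 log units; beyond the scatter), and ethyl in place of piperidin-1-yl gives a 9.2-fold higher number from compound 2 to compound 4 (0.96 log units; beyond the scatter), so in these four compounds the lower numbers go with the two amine chain ends and the higher numbers with the two all-carbon ones. Nothing available explains this separation.

Still open, as far as these compounds go, is whether a primary amine at the chain end would keep the lower number, and what a carboxylic acid there would do. Also open, from the compounds shown here alone, is how a longer chain carrying dimethylamino would read.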